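The compounds below may be only part of what the source reports. "The series", "measured", "known", "first", "only" and "open" are said of these compounds alone.

Compound 1 `NC(=O)c1ccc(-c2cccnc2)cc1OC1CCNCC1` gives 1100 nM in an assay on cells for inhibition of MAP kinase-interacting serine/threonine-protein kinase 1 (Homo sapiens), read by mobility shift assay, with stated times of 10 min and 60 min, in the presence of a further agent that is not named here; a lower number here means a stronger inhibitor, a higher number a weaker inhibitor. Compound 2 `CC(=O)c1cncc(-c2ccc(C(N)=O)cc2)c1` gives 8000 nM in this assay. Compound 3 `Cc1n[nH]c(C)c1-c1cncc(-c2ccc(C(N)=O)c(OC(C)C)c2)c1` gives 33 nM in this assay.

Among these three numbers, compound 1 stands second highest: compound 2 shows a higher number, compound 3 a far lower one, and both gaps lie beyond the usual scatter of repeated measurements. Compound 4 `NCCOc1cc(-c2cccnc2)ccc1C(N)=O` is made from compound 1 by one change: 2-aminoethyl in place of piperidin-4-yl on an oxygen on an aromatic ring. For the measured compounds named here, no measured pair shows the effect of such a change here, so the expectation rests on compound 1 alone. The donor and acceptor count stays the same while the ring is lost, and a step of modest size toward a higher number, or none beyond the scatter, is expected. For compound 4 the expected value is 2000 nM, with a range from 700 nM to 6000 nM, meaning an expected step of a 1.8-fold higher number from compound 1 to compound 4 (0.26 log units; within the scatter).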

Compound 4, half-maximal inhibitory concentration: 820 nM
Beside the measured number, compound 4's estimate is 2.4-fold (0.39 log units) above it; the range from low to high includes it.
By their numbers in this assay, from the lowest: compound 3; then compounds 4 and 1 (each within the scatter of the next); then compound 2.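

In this assay the change from piperidin-4-yl to 2-aminoethyl on this oxygen gives a 1.3-fold lower number from compound 1 to compound 4 (0.13 log units; within the scatter) and so stays within the scatter. In this pair, the six-membered ring can therefore give way to an open chain without a measurable shift in the number. Nothing measured here explains why the two groups read alike. Going by these compounds, it remains open whether a longer chain such as 3-aminopropyl would read the same at this oxygen. A group without an amine, such as methyl or 2-hydroxyethyl, also remains to be compared there.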